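This account rests on a few compounds, and the source may have more. Where it says the series, first, only, none or still open, it means among the compounds named here.

Measured in a functional assay on Ehrlich cells (Mus musculus) for antiproliferative activity, read by trypan blue exclusion, with a stated time of 2 h, tested at 25 ug/mL; on this read-out lower numbers stand for a weaker effect and higher numbers for a stronger effect at the one concentration tested:
compound 1 `Cc1ccc(C2C(C#N)=C(N)N(c3ccc(S(N)(=O)=O)cc3)C3=C2C(=O)CCC3)cc1` gives 30%
compound 2 `N#CC1=C(N)N(c2ccc(S(N)(=O)=O)cc2)C2=C(C(=O)CCC2)C1c1ccc(O)cc1` gives 95%
compound 3 `COc1ccccc1C1C(C#N)=C(N)N(c2ccc(S(N)(=O)=O)cc2)C2=C1C(=O)CCC2` gives 0%

Compound 2 stands highest of these three in this assay; compound 1 is nearest and compound 3 furthest, both beyond the scatter. Compound 4 `N#CC1=C(N)N(c2ccc(S(N)(=O)=O)cc2)C2=C(C(=O)CCC2)C1c1cccc([N+](=O)[O-])c1` differs from compound 2 in one place: 3-nitrophenyl in place of 4-hydroxyphenyl on a saturated ring carbon. For the measured compounds named here, two measured steps bear on this, both exchanging the aryl group on the same saturated ring carbon: a number 65 percentage points higher from compound 1 to compound 2 (beyond the scatter) and a number 95 percentage points lower from compound 2 to compound 3 (beyond the scatter). Each time the 4-hydroxyphenyl compound stood far above its partner, so a large downward step is expected in this assay for the nitro compound too. Compound 4 is expected at 30%, with a range from 5% to 65%. The estimated step is a number 65 percentage points lower from compound 2 to compound 4 (beyond the scatter).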

Compound 4, a percentage reported as activity, at one concentration (the size of the read-out at that concentration, not a potency): 50%
Estimate against measurement, compound 4: 20 percentage points below, within the range that was stated.
By their numbers in this assay, from the lowest: compound 3; then compound 1; then compound 4; then compound 2.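

In this assay, 3-nitrophenyl on this saturated ring carbon falls short of 4-hydroxyphenyl (a number 45 percentage points lower from compound 2 to compound 4 (beyond the scatter)) but stands clear of 2-methoxyphenyl (a number 50 percentage points higher from compound 3 to compound 4 (beyond the scatter)) and 4-methylphenyl (a number 20 percentage points higher from compound 1 to compound 4 (beyond the scatter)). At this position, then, a substantial effect does not require the hydroxy group, although compound 2 remains the highest of the four. No evidence at hand accounts for this order.

From the compounds shown here alone, whether the hydroxy or nitro result depends on where the group sits on the phenyl ring remains open. Going by these compounds, what an amine or a carboxylic acid on that phenyl would give also remains open.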